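The source may hold more compounds than are shown below. What is called first, only, known or untested is meant among the compounds shown, and "the series" means these compounds.

The three measured compounds are compound 1 `CC(C)N(Cc1cccc(OCCCCCC(=O)O)c1)C(=O)c1ccc(-c2ccc3c(c2)OCCO3)cc1`, compound 2 `CCOC(=O)CCCCCOc1cccc(CN(C(=O)c2ccc(-c3cccc(CC(=O)O)c3)cc2)C(C)C)c1` and compound 3 `CCOC(=O)CCCCCOc1ccc(CNC(C)C)cc1`, all tested in an ADME assay on HepG2 cells (Homo sapiens) for cytotoxicity, read by CellTiter-Glo and resazurin assay, with a stated time of 72 h; a lower number here means that less compound is needed, a higher number that more compound is needed for the effect. For compound 1 the result is only a limit of the assay, > 21900 nM. For compound 2 the result is likewise a limit, > 26000 nM. Compound 3 also gives no number but a limit, > 26000 nM. Thus compound 3 stands among results that are all limits: one value sits at the limit of > 21900 nM in this assay, at which 1 of the 3 values shown sits, and two, compound 3 among them, sit at the limit of > 26000 nM in this assay, at which 2 of the 3 values shown sit, so nothing in this assay separates compound 3 from the other two.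

The unmeasured compound 4 `CCOC(=O)CCCCCOc1ccc(C=O)cc1` differs from compound 3 in one place: formyl in place of (isopropylamino)methyl on an aromatic carbon. Within the data shown here, no measured step between two compounds is available to show how such a change acts in this assay, and the measured compounds give only limits, no numbers. Compound 3 shows only a limit in this assay, > 26000 nM. No shift beyond the usual scatter is expected in either direction, so the expected step is a step that the limit leaves unreadable from compound 3 to compound 4. In this assay compound 4 is therefore estimated at 30000 nM, with a range from 10000 nM to 100000 nM, and the result is expected most likely to come back as a limit rather than a number.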

Compound 4, half-maximal effective concentration: > 26000 nM
Compound 4: only a limit was reported (the forecaster's own chance of this, stated with the estimate: 80%); the middle value does not contradict the limit.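

Compound 3 and compound 4 both return only limits in this assay, so no step can be read from the change of (isopropylamino)methyl to formyl. The compounds shown leave open whether any of them would give an actual number in this assay, and how such a change would then act.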